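The compounds below may be only part of what the source reports. "The series", "measured", "known", "first", "only" and "open" are said of these compounds alone.

Compound 1 `O=[N+]([O-])c1ccc(COc2ccc(Nc3ncnc4cc5c(cc34)OCCOCCO5)cc2)cc1` belongs to a small set of three measured compounds tested in a functional assay on HepG2 cells (Homo sapiens) for antiproliferative activity, read by MTT assay, with a stated time of 72 h; a lower number here means a stronger inhibitor, a higher number a weaker inhibitor. In this assay compound 1 gives > 100000 nM, which is a limit of the assay rather than a number. Compound 2 `FC(F)(F)c1ccc(COc2cccc(Nc3ncnc4cc5c(cc34)OCCOCCO5)c2)cc1` gives > 100000 nM in this assay, again only a limit. Compound 3 `FC(F)(F)c1ccc(COc2cccc(Nc3ncnc4cc5c(cc34)OCCOCCOCCO5)c2)cc1`, whose core carries one more oxyethylene unit, gives 34000 nM in this assay, a measured number. Compound 1 thus stands at the upper edge of the assay, and the limit of > 100000 nM in this assay, at which 2 of the 3 values shown sit, shows that two of the three values sit there, so nothing on these numbers separates compound 1 from compound 2.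

Compound 4 `c1ccc(COc2ccc(Nc3ncnc4cc5c(cc34)OCCOCCO5)cc2)cc1` has not yet been tested. It differs from compound 1 in one place (hydrogen in place of nitro on an aromatic carbon). For the measured compounds named here, no two measured compounds differ in only one place, so no measured step guides the expectation. Because compound 1 sits at the limit of > 100000 nM in this assay, at which 2 of the 3 values shown sit, the expected step of a number no higher from compound 1 to compound 4 (the limit leaves the size open) is none beyond the scatter, and the result may again be only a limit. Compound 4 is expected to give 100000 nM in this assay, within a range from 30000 nM to 300000 nM.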

Compound 4, half-maximal inhibitory concentration: 55500 nM
Compound 4: middle estimate off by 1.8-fold (0.26 log units), on the high side; measured number inside the range.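

In this assay, for the compounds shown here, hydrogen in place of nitro on this aromatic carbon, para to a large group, gives an at least 1.8-fold lower number from compound 1 to compound 4 (0.25 log units; that floor lies within the scatter), the first step in the set that can be read at all. Compound 4 shows that, with a plain benzyloxy group in place of (4-nitrobenzyl)oxy, this core can yield a measured number rather than a limit, yet the printed floor of the step does not by itself establish a real gain. The true size of the step stays open because compound 1 gives only a limit: the limit of > 100000 nM in this assay, at which 2 of the 4 values shown sit.

The compounds shown leave open whether a different group at this position, such as an amine or a methoxy group, would move the number in either direction. They also leave open whether removing nitro would have a similar effect on the core with one more oxyethylene unit.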